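The source may report more compounds than this note shows. Statements on the series, on what has been measured and on what is new or still open speak of the compounds shown alone.

Measured compounds in this series:
- compound 1 `C[C@@H](O[C@@H]1CN(C(=O)N2CCOCC2)C[C@H]1c1ccccc1)c1cc(C(F)(F)F)cc(C(F)(F)F)c1`: 0.16 nM
- compound 2 `CCNC(=O)N1C[C@@H](O[C@H](C)c2cc(C(F)(F)F)cc(C(F)(F)F)c2)[C@H](c2ccc(F)cc2)C1`: 0.1 nM

In an assay on CHO cells for displacement of a labelled ligand from Substance-P receptor (Homo sapiens) (on this read-out higher numbers stand for weaker inhibition and lower numbers for stronger inhibition), compound 1 gives 0.16 nM, the higher of the two numbers shown; compound 2 gives 0.1 nM, and the gap between the two lies within the scatter, so no order can be read from them. Compound 3 `C[C@@H](O[C@@H]1CN(C2=CC(=O)C(C)(C)CC2)C[C@H]1c1ccccc1)c1cc(C(F)(F)F)cc(C(F)(F)F)c1` is not yet measured. It differs from compound 1 by 4,4-dimethyl-3-oxocyclohex-1-en-1-yl in place of (morpholin-4-yl)carbonyl on an amine nitrogen in a ring. Within the data shown here, no step between measured compounds bears on this change, so only a guess is possible. The urea-type substituent is replaced by a ring carrying a ketone; a modest move toward a higher number is expected, from compound 1 to compound 3 estimated at a 3.1-fold higher number from compound 1 to compound 3 (0.49 log units; beyond the scatter). Compound 3 is expected to give about 0.5 nM in this assay, within 0.1 nM to 3 nM.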

Compound 3, half-maximal inhibitory concentration: 0.18 nM
Compound 3: middle estimate off by 2.8-fold (0.44 log units), on the high side, and the stated range covers the measured number.
By their numbers in this assay, from the lowest: compounds 2, 1 and 3 (each within the scatter of the next).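

In this assay, 4,4-dimethyl-3-oxocyclohex-1-en-1-yl replaces (morpholin-4-yl)carbonyl on the amine nitrogen in the ring with a 1.1-fold higher number from compound 1 to compound 3 (0.05 log units; within the scatter). This place on the core therefore accepts a six-membered ring of carbon only as well as one with 2 hetero atoms, and the (morpholin-4-yl)carbonyl group is not needed to keep the read-out in this range. Nothing on hand explains why the two groups read alike. Still open, on these data alone, is how a carboxylic acid or a longer chain ending in an amine would read on this nitrogen.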